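From 2-methoxyphenyl to 3-hydroxyphenyl on a carbonyl carbon

The source may hold more compounds than are shown below. What is called first, only, known or untested is meant among the compounds shown, and "the series" means these compounds.

In an ADME assay on 3T3 cells (Rattus norvegicus) for cytotoxicity against 3T3 (Mus musculus), read by MTT assay (a lower number here means a stronger inhibitor, a higher number a weaker inhibitor), compound 2 `COc1ccccc1C(=O)CSc1nnc(-c2ccc(OCc3ccccc3)cc2)o1` gives > 30000 nM as a limit of the assay, not a number. Compound 1 `O=C(CSc1nnc(-c2ccc(Cl)cc2)o1)c1cccc(O)c1` gives > 30000 nM as a limit too. For the measured compounds named here, the series so far offers the limit of > 30000 nM in this assay, at which 2 of the 2 values shown sit, and no measured step, so the position of compound 2 is known only as a limit.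

Going by the values given here, compound 3 `O=C(CSc1nnc(-c2ccc(OCc3ccccc3)cc2)o1)c1cccc(O)c1` comes from compound 2 through 3-hydroxyphenyl in place of 2-methoxyphenyl on a carbonyl carbon as the only change, with 3-hydroxyphenyl in place of 2-methoxyphenyl on a carbonyl carbon.

The expected size of a number no higher from compound 2 to compound 3 (the limit leaves the size open) in either direction is nothing beyond the scatter. That expectation rests on compound 1, whose > 30000 nM is also a limit with the same 3-hydroxyphenyl in place. Compound 3 is estimated at 30000 nM with an expected range from 15000 nM to 60000 nM and will most likely be reported as a limit again.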

Compound 3, half-maximal inhibitory concentration: > 30000 nM
Compound 3 ended at the assay's limit; the forecaster's own chance of this, stated with the estimate: 85%; the middle value sits exactly at the limit.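

The steps from compound 2 to compound 3 and from compound 1 to compound 3 cannot be read, as all three values are limits and not numbers: the limit of > 30000 nM in this assay, at which 3 of the 3 values shown sit.

The compounds shown leave open whether 3-hydroxyphenyl in place of 2-methoxyphenyl, or benzyloxy in place of chloro, changes the half-maximal inhibitory concentration at all.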